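Butylamino diaminopyrimidine halogen swap at Toll-like receptor 8

The compounds below may be only part of what the source reports. "The series", "measured", "known", "first", "only" and "open" are said of these compounds alone.

Compound 1 `CCCCNc1nc(N)nc(C)c1I`: 1640 nM
Compound 2 `CCCCNc1nc(N)nc(C)c1Cl`: 20000 nM

Compound 1 gives the lowest of the two numbers in an assay on HEK293 cells for agonist activity at Toll-like receptor 8 (Homo sapiens), read by reporter gene assay (a lower number here means that less compound is needed, a higher number that more compound is needed for the effect), with compound 2 the nearest at a 12-fold higher number from compound 1 to compound 2 (1.09 log units; beyond the scatter). Compound 3 `CCCCNc1nc(N)nc(C)c1F` differs from compound 1 by fluoro in place of iodo on an aromatic carbon. For the measured compounds named here, the only step that bears on this change is the one from iodo to chloro, a 12-fold higher number from compound 1 to compound 2 (1.09 log units; beyond the scatter), which was large. A further move to fluoro is therefore expected to give a step at least as large and in the same direction, a 24-fold higher number from compound 1 to compound 3 (1.39 log units; beyond the scatter). Compound 3 is estimated at 40000 nM, within 12000 nM to 120000 nM.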

Compound 3, half-maximal effective concentration: 34000 nM
Compound 3: the middle estimate sits 1.2-fold (0.07 log units) above what was measured; low and high end bracket the measured number.
By their numbers in this assay, from the lowest: compound 1; then compounds 2 and 3 (each within the scatter of the next).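

In this assay, fluoro in place of iodo on this aromatic carbon gives a 21-fold higher number from compound 1 to compound 3 (1.32 log units; beyond the scatter), so the shift seen with chloro is not particular to that one halogen. Fluoro in place of chloro gives only a 1.7-fold higher number from compound 2 to compound 3 (0.23 log units; within the scatter), which leaves compounds 2 and 3 unseparated and compound 1, with iodo, alone at the lowest number. Nothing given here explains why iodo stands apart.

Going by these compounds, whether bromo at this carbon would fall with iodo or with the other two halogens remains open. Also open, on these data alone, is whether a longer chain in place of the group of 5 heavy atoms would keep the iodo step at this size.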